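This account rests on a few compounds, and the source may have more. Where it says the series, first, only, none or still open, it means among the compounds named here.

Working notes on this series. In an assay on isolated protein for inhibition of Dihydrofolate reductase (Homo sapiens), read by spectrophotometry, using NADPH, with stated times of 5 s and 6 min, tested at 5 uM (a higher number here means a stronger effect of the compound at the concentration tested, a lower number a weaker effect), compound 2, `NC1=NC2(CCOCC2)N(OCCCOc2cccc(Cl)c2Cl)C(N)=N1`, gives 81.7%. Compound 3, `NC1=NC2(CCSCC2)N(OCCCOc2cccc(Cl)c2Cl)C(N)=N1`, gives 83.8% in this assay, and compound 1, `CC(C)(C)c1ccc(OCCCON2C(N)=NC(N)=NC23CCSCC3)cc1`, gives 85.3%; all three numbers lie within the scatter of one another, so no ranking among them is supported. For the measured compounds named here, no step between two measured compounds that differ in one place is available, so the bearing of the aryl substitution pattern is untested. Compound 4, `NC1=NC2(CCOCC2)N(OCCCOc2ccc(Cl)c(Cl)c2)C(N)=N1`, is not yet measured. Its difference from compound 2: 3,4-dichlorophenyl in place of 2,3-dichlorophenyl on an oxygen on a saturated carbon. Given that the three measured compounds sit so close, a step expected to stay within the scatter, with no direction that can be argued from the data, seems the fair call: a number 1.7 percentage points lower from compound 2 to compound 4 (within the scatter). Compound 4 is therefore estimated at 80% in this assay, with a range from 65% to 92%.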

Compound 4, a percentage reported as inhibition, at one concentration (the size of the read-out at that concentration, not a potency): > 90%
Compound 4 ended at the assay's limit (the forecaster's own chance of this, stated with the estimate: 0%); middle value at least 10 percentage points away from the limit.
By their numbers in this assay, from the lowest: compounds 2, 3 and 1 (each within the scatter of the next). At a limit, above all of these: compound 4.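

For the compounds shown here, this is the first step between compounds that differ in one place: 3,4-dichlorophenyl in place of 2,3-dichlorophenyl on an oxygen on a saturated carbon gives a number at least 8.3 percentage points higher from compound 2 to compound 4 (that floor lies within the scatter) in this assay. Compound 4 gives > 90%, which is a limit of the assay and not a number. The exchange of chlorine pattern therefore may matter at this position, but neither a real change nor its full size is established.

From the compounds shown here alone, whether the same exchange would act alike on the core of compound 3 remains open. Also open, going by these compounds, is how an amine or a carboxylic acid would read in place of the dichlorophenyl group.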